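The source may report more compounds than this note shows. Statements on the series, on what has been measured and on what is new or still open speak of the compounds shown alone.

Series notes. The three measured compounds share the core of compound 1 `OC[C@H]1O[C@@H](n2cnc3c(SCc4ccccc4Br)ncnc32)[C@H](O)[C@@H]1O` and differ only in the substituent on the benzyl ring. In an assay on isolated protein for inhibition of Equilibrative nucleoside transporter 1 (Homo sapiens) (on this read-out higher numbers stand for weaker inhibition and lower numbers for stronger inhibition), compound 1 gives 151 nM. Compound 2 `OC[C@H]1O[C@@H](n2cnc3c(SCc4ccccc4I)ncnc32)[C@H](O)[C@@H]1O` gives 19.5 nM in this assay, the lowest of the three numbers; compound 3 `O=[N+]([O-])c1ccccc1CSc1ncnc2c1ncn2[C@@H]1O[C@H](CO)[C@@H](O)[C@H]1O` gives 115 nM. The steps run a 7.7-fold lower number from compound 1 to compound 2 (0.89 log units; beyond the scatter), a 5.9-fold higher number from compound 2 to compound 3 (0.77 log units; beyond the scatter) and a 1.3-fold lower number from compound 1 to compound 3 (0.12 log units; within the scatter), so compound 2 stands apart from both neighbours while compound 1 and compound 3 sit within the scatter of each other.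

Compound 4 `Cc1cccc(CSc2ncnc3c2ncn3[C@@H]2O[C@H](CO)[C@@H](O)[C@H]2O)c1` is not yet measured. It differs from compound 2 by 3-methylphenyl in place of 2-iodophenyl on a saturated chain carbon bound to a sulfur. Among the compounds with values here, no measured step covers this exact change. What bears on it is that both measured departures from the iodo compound raised the number by a modest amount, and that the two non-iodo compounds sit close together. A modest rise in this assay is therefore expected; the expected change is a 7.7-fold higher number from compound 2 to compound 4 (0.89 log units; beyond the scatter). Compound 4 is estimated at 150 nM, with a range from 50 nM to 500 nM.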

Compound 4, inhibition constant: 16.2 nM
For compound 4 the middle estimate is 9.3-fold (0.97 log units) above the measured one; the measured number lies below the stated range.
By their numbers in this assay, from the lowest: compounds 4 and 2 (each within the scatter of the next); then compounds 3 and 1 (each within the scatter of the next).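

In this assay the low numbers in this series prove not to belong to iodo alone: 3-methylphenyl in place of 2-iodophenyl gives a 1.2-fold lower number from compound 2 to compound 4 (0.08 log units; within the scatter) and so stays level with the iodo compound. The same group keeps a gap to the nitro and bromo compounds, with a 7.1-fold lower number from compound 3 to compound 4 (0.85 log units; beyond the scatter) and with a 9.3-fold lower number from compound 1 to compound 4 (0.97 log units; beyond the scatter) in the same direction, so a benzyl ring without any halogen or nitro group can join the low pair. No information at hand accounts for this result.

Because 3-methylphenyl differs from 2-iodophenyl in both the group and its ring position, the compounds shown do not separate those two changes. As far as these compounds go, how an amine, a carboxylic acid or a longer chain on the benzyl ring would read in this assay also stays open.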